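From 4-fluorophenoxy to 4-bromophenoxy: compound 1 to compound 3

The source may hold more compounds than are shown below. What is called first, only, known or untested is meant among the compounds shown, and "the series" means these compounds.

Measured so far:
- compound 1 `COc1cc2c(cc1CC=C(C)C)C(=O)C[C@@H](c1ccc(Oc3ccc(F)cc3)cc1)O2`: 29%
- compound 2 `COc1ccc([C@@H]2C/C(=N/OCc3cn(-c4ccc(NC(C)=O)cc4)nn3)c3cc(CC=C(C)C)c(OC)cc3O2)cc1`: 6%

In a functional assay on HCT-116 cells (Homo sapiens) for inhibition, read by sulforhodamine B assay, with a stated time of 48 h, tested at 50 uM (a lower number here means less inhibition of growth, a higher number more inhibition of growth at the concentration tested), compound 1 stands highest at 29%, while compound 2 gives 6%, lower by more than the scatter. Compound 3 `COc1cc2c(cc1CC=C(C)C)C(=O)C[C@@H](c1ccc(Oc3ccc(Br)cc3)cc1)O2` carries bromo in place of fluoro on an aromatic carbon, para to a large group (bromo in place of fluoro on an aromatic carbon). Among the compounds with values here, no measured pair yet shows such a change, so the expectation rests on compound 1 at 29%. The expected a number 3 percentage points higher from compound 1 to compound 3 (within the scatter) is small and upward, not beyond the scatter. The estimated value for compound 3 is 32%, with an expected range of 18% to 48%.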

Compound 3, percent growth inhibition at one concentration: 76%
Beside the measured number, compound 3's estimate is 44 percentage points below it; the measured number lies above the stated range.
By their numbers in this assay, from the lowest: compound 2; then compound 1; then compound 3.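

In this assay, the halogen on the 4-phenoxy group proves to be a sensitive point of the series: bromo in place of fluoro gives a number 47 percentage points higher from compound 1 to compound 3 (beyond the scatter) on an otherwise unchanged core. The exchange swaps one heavy atom for one heavy atom and alters no ring, hydrogen-bond donor, hydrogen-bond acceptor or net charge. Nothing at hand accounts for the size of this step. Going by these compounds, with only fluoro and bromo compared at this place, it remains open how chloro, iodo, methoxy or an amine there would read.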